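A few compounds are considered here, and "the series" means these few. Any claim that something is new, unique, unknown or untested is made for them only; others in the source may bear on it.

Compound 1 `COc1cc(/C=N/Nc2nc(-c3ccc(Br)cc3)cs2)cc(Br)c1OC` and compound 2 `COc1cc(/C=N/Nc2nc(-c3cccc(Br)c3)cs2)cc(Br)c1OC` share a core; in a functional assay on A549 cells (Homo sapiens) for inhibition, read by MTT assay, with a stated time of 48 h (on this read-out lower numbers stand for stronger inhibition and higher numbers for weaker inhibition), compound 1 gives 52300 nM, and compound 2 gives 56000 nM. Between them the change 4-bromophenyl in place of 3-bromophenyl on an aromatic carbon made the step of a 1.1-fold lower number from compound 2 to compound 1 (0.03 log units; within the scatter). Compound 3 `Fc1ccc(/C=N/Nc2nc(-c3cccc(Br)c3)cs2)cc1F` gives 16200 nM in this assay, the lowest of the three numbers, beyond the scatter from both compound 1 and compound 2. The difference between the core of compound 3 and the core of compound 2 is not broken down here. Compound 4 `Fc1ccc(/C=N/Nc2nc(-c3ccc(Br)cc3)cs2)cc1F` is not yet measured; it differs from compound 3 by 4-bromophenyl in place of 3-bromophenyl on an aromatic carbon, the same kind of change as from compound 2 to compound 1. Since that earlier step lay within the scatter, compound 4 is expected to stay close to compound 3, with an estimated step of a 1.1-fold lower number from compound 3 to compound 4 (0.03 log units; within the scatter). Compound 4 is thus estimated at 15000 nM, expected to fall between 7000 nM and 35000 nM.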

Compound 4, half-maximal inhibitory concentration: > 100000 nM
Compound 4: only a limit was reported; the forecaster's own chance of this, stated with the estimate: 5%; middle value at least 6.6-fold (0.82 log units) from the limit.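

In this assay, 4-bromophenyl in place of 3-bromophenyl gives an at least 6.1-fold higher number from compound 3 to compound 4 (0.79 log units; beyond the scatter), so the change does not carry over from one core to the other: the same change on two cores in this assay, a 1.1-fold lower number (0.03 log units; within the scatter) from compound 2 to compound 1 and an at least 6.1-fold higher number (0.79 log units; beyond the scatter) from compound 3 to compound 4, at least 6.6-fold (0.82 log units) apart, beyond the scatter of two such steps. As far as these compounds go, compound 4 gives > 100000 nM, which is a limit and not a number, so the full size of this step stays unknown: the limit of > 100000 nM in this assay, at which 1 of the 4 values shown sits. Two pairs show that the outcome of this change can depend on the core, but they do not show which part of the core matters or give a rule for other cores.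

The compounds shown leave open whether 4-chlorophenyl or 4-methoxyphenyl in the same place would split in the same way between these two cores. They also leave open how a core carrying an amine would respond to the change.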